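Shifting a Chlorine on a Shared Core

The compounds below may be only part of what the source reports. "The series", "measured", "known", "first", "only" and "open" are said of these compounds alone.

Three close relatives share one core and differ only in the groups attached to it. Compound 1 `Oc1cccc(-c2cc(-c3cccnc3)nc(-c3cccc(Cl)c3)c2)c1` in a functional assay on HCT-15 cells (Homo sapiens) for cytotoxicity, read by CCK-8 assay and cell counting, with a stated time of 2 days (a higher number here means a weaker inhibitor, a lower number a stronger inhibitor), is reported as "not determined" (no result reported), so it offers no number to lean on. Within the data shown here, compound 2 `Oc1cccc(-c2cc(-c3ccccc3)nc(-c3ccc(Cl)cc3)c2)c1` is the one measured member of the set, and in this assay compound 2 gives 8110 nM. Because that is the only number shown, compound 2 stands alone as the reference point, with nothing to rank it against.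

Compound 3 `Oc1cccc(-c2cc(-c3ccccc3)nc(-c3cccc(Cl)c3)c2)c1` has not yet been measured. Compared with compound 2 it has the same atoms joined differently: 3-chlorophenyl in place of 4-chlorophenyl on an aromatic carbon. The whole change is thus the position of the chlorine on that outer ring.

Among the measured compounds shown here, no measured pair shows what such a shift does on this core, so the expectation rests on compound 2 alone, whose value of 8110 nM sets the anchor. The expected step of a 1.2-fold lower number from compound 2 to compound 3 (0.06 log units; within the scatter) is small, not clearly beyond the usual scatter, and without a firm direction. Compound 3 is therefore estimated at 7000 nM in this assay, with a likely range from 2500 nM to 25000 nM.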

Compound 3, half-maximal inhibitory concentration: 2550 nM
Compound 3: the middle estimate sits 2.7-fold (0.44 log units) above what was measured; the range from low to high includes it.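

With 3-chlorophenyl in place of 4-chlorophenyl, the reading in this assay shows a 3.2-fold lower number from compound 2 to compound 3 (0.50 log units; beyond the scatter) as a modest change, yet one that lies beyond the usual scatter. Among these compounds, this is the first sign that, on the shared core, the number responds to where the chlorine sits on this outer ring, even though the two compounds contain exactly the same atoms. The result rests on a single pair, and nothing available explains why the number moves, so no cause can be named here.

Compound 1 also carries 3-chlorophenyl but gives no number, so it cannot show whether the same shift would matter with its different second ring on the shared core. Also open is whether chlorine itself matters at this spot, since the compounds shown leave unanswered how this outer ring would behave with no substituent at all, or with a fluorine, a methoxy group or an amine in place of the chlorine.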